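Shortening the Chain on a Triazene Amide

The source may report more compounds than this note shows. Statements on the series, on what has been measured and on what is new or still open speak of the compounds shown alone.

Compound 1 `CCOC(=O)c1ccc(/N=N/N(C)CC(C)C)cc1`: 2.8
Compound 2 `CCCCN(C)/N=N/c1c(C(N)=O)n[nH]c1C`: 3.83
Compound 3 `CCOC(=O)c1[nH]c(-c2ccccc2)nc1/N=N/N(C)C`: 3.48

In a functional assay on L1210 cells (Mus musculus) for antiproliferative activity (on this read-out higher numbers stand for higher potency (the scale is a negative logarithm) and lower numbers for lower potency), compound 2 stands highest of the three numbers: compound 3 lies lower by a margin beyond the usual scatter, and compound 1 lower still. Compound 4 `Cc1[nH]nc(C(N)=O)c1/N=N/N(C)C` is compound 2 with a single change:

hydrogen in place of propyl on a saturated chain carbon bound to an amine nitrogen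

Among the measured compounds shown here, no step between two measured compounds isolates this change, so its effect is not known from the measured data. Compounds 1 and 3 carry a methyl rather than a butyl on the same kind of nitrogen and give lower numbers, but their cores differ from that of compound 2 as well. The step from compound 2 to compound 4 is expected to be a modest drop, a number 0.33 log units lower from compound 2 to compound 4 (beyond the scatter), close to the edge of the scatter. Compound 4 is estimated at 3.5, with a range from 2.9 to 4.1.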

Compound 4, logarithm of the reciprocal of the active concentration, log(1/C): 3.84
Compound 4: middle estimate off by 0.34 log units, on the low side, and the stated range covers the measured number.
By their numbers in this assay, from the lowest: compound 1; then compound 3; then compounds 2 and 4 (each within the scatter of the next).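

In this assay, the step from butyl to methyl on the amine nitrogen gives a number 0.01 log units higher from compound 2 to compound 4 (within the scatter) on an otherwise unchanged core. Among the compounds shown here, this is the first direct reading of this position, and it shows that the propyl portion can go without a measurable loss in this read-out. Nothing on hand explains why the number holds.

From the compounds shown here alone, a longer chain, or a chain ending in an amine or a carboxylic acid, remains open at this position. So does whether butyl and methyl also match on the cores of compound 1 and compound 3.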